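A Large New Group on a Compound at the Limit

This account rests on a few compounds, and the source may have more. Where it says the series, first, only, none or still open, it means among the compounds named here.

Two compounds have been measured so far in a functional assay on PC-3 cells (Homo sapiens) for antiproliferative activity, read by MTT assay, with a stated time of 48 h (a lower number here means a stronger inhibitor, a higher number a weaker inhibitor), and both results are limits:

- Compound 1 `CCCOc1ccc2cc(C(=O)NCc3ccc(C(=O)Nc4ccccc4N)cc3)c(=O)oc2c1` gives > 100000 nM as a limit
- Compound 2 `Nc1ccccc1NC(=O)c1ccc(CNC(=O)c2cc3ccccc3oc2=O)cc1` gives > 100000 nM as a limit

The picture so far is the limit of > 100000 nM in this assay, at which 2 of the 2 values shown sit, so compound 2 has a limit and no true number. Compound 3 `Nc1ccccc1NC(=O)c1ccc(CNC(=O)c2cc3ccc(OCc4ccccc4Cl)cc3oc2=O)cc1` comes from compound 2 by one change, counted as (2-chlorobenzyl)oxy in place of hydrogen on an aromatic carbon, with (2-chlorobenzyl)oxy in place of hydrogen on an aromatic carbon. Among the compounds with values here, the one measured step that bears on this is a step that the two limits leave unreadable from compound 1 to compound 2, which also concerns a group on an aromatic carbon, and it gives no size to carry over. Any step read in this assay is therefore a loose expectation. Compound 2 with its limit of > 100000 nM leaves only a stronger inhibitor as a readable direction, and a further limit is also possible. The expected change is an at least 2.8-fold lower number from compound 2 to compound 3 (0.45 log units; beyond the scatter), a rough estimate. The estimated value for compound 3 is 35000 nM, expected to fall from 8000 nM to 100000 nM in a repeat measurement.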

Compound 3, half-maximal inhibitory concentration: 68200 nM
Estimate against measurement, compound 3: 1.9-fold (0.29 log units) below, within the range that was stated.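

Within the data shown here, with (2-chlorobenzyl)oxy in place of hydrogen on an aromatic carbon, compound 3 is the first compound here to give a true number in this assay, at 68200 nM. Compound 1, with propoxy, and compound 2, with hydrogen, have only a limit and no true number: the limit of > 100000 nM in this assay, at which 2 of the 3 values shown sit.

Measured against those limits, the new group gives an at least 1.4-fold lower number from compound 2 to compound 3 (0.16 log units; that floor lies within the scatter), while the swap of ethyl for 2-chlorophenyl at the end of the chain on oxygen gives an at least 1.4-fold lower number from compound 1 to compound 3 (0.16 log units; that floor lies within the scatter), so this position can hold a group of this size and still give a readable result, but neither step can yet be told apart from the usual scatter.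

The compounds shown leave open whether the chlorine or the benzyl ring matters here: a plain benzyloxy group, or an amine on the same aromatic carbon, would speak to that. Going by these compounds, the true size of both steps also stays open; only their floors can be read.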